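Aryl-for-aryl exchange on the piperazine nitrogen: compound 4

The source may hold more compounds than are shown below. What is called first, only, known or untested is meant among the compounds shown, and "the series" means these compounds.

Measured so far in an assay on membranes from brain for displacement of a labelled ligand from Sigma non-opioid intracellular receptor 1 (Cavia porcellus), read by scintillation counting, with a stated time of 120 min; a lower number here means a stronger inhibitor, a higher number a weaker inhibitor:
- compound 1 `CCCCCCN1CCN(CCC(=O)Nc2nc3c(C)cccc3s2)CC1` gives 238 nM
- compound 2 `Cc1cccc2sc(NC(=O)CCN3CCN(C4CCCCC4)CC3)nc12` gives 24 nM
- compound 3 `Cc1ccccc1N1CCN(CCC(=O)Nc2nc3c(C)cccc3s2)CC1` gives 1000 nM

Compound 3 has the highest number of the three; the nearest is compound 1 with a 4.2-fold higher number from compound 1 to compound 3 (0.62 log units; beyond the scatter), and the step of a 42-fold higher number from compound 2 to compound 3 (1.62 log units; beyond the scatter) is the widest gap in the set. Within these three, placing an aromatic ring on the ring amine nitrogen has twice gone with a higher number, once from the hexyl chain and once from cyclohexyl.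

Compound 4 `Cc1cccc2sc(NC(=O)CCN3CCN(c4ccccn4)CC3)nc12` differs from compound 3 by pyridin-2-yl in place of 2-methylphenyl on an amine nitrogen in a ring.

Among the measured compounds shown here, both steps that end in compound 3 bear on this position, but each exchanges an aromatic ring for a saturated group; none of the measured steps exchanges one aromatic ring for another, and no measured compound carries a ring nitrogen or a hydrogen-bond acceptor at this site. The trend so far gives the aromatic substituent the weaker numbers, and the new group keeps an aromatic ring there. The step from compound 3 to compound 4 is therefore expected to be small, with a lean toward a somewhat higher number, estimated as a 1.5-fold higher number from compound 3 to compound 4 (0.18 log units; within the scatter). For compound 4 the expected value in this assay is 1500 nM, with a range from 400 nM to 6000 nM.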

Compound 4, inhibition constant: 1000 nM
The estimate for compound 4 lay 1.5-fold (0.18 log units) above the measured number; measured number inside the range.
By their numbers in this assay, from the lowest: compound 2; then compound 1; then compounds 3 and 4 (each within the scatter of the next).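

In this assay, among the compounds shown here, the step from 2-methylphenyl to pyridin-2-yl on the amine nitrogen in a ring is the first aromatic-for-aromatic exchange at this position, and it reads no change at the digits printed from compound 3 to compound 4 (within the scatter); a ring nitrogen and a hydrogen-bond acceptor thus enter here, and the methyl leaves, without any separation between the two compounds. The aromatic ring now carrying that nitrogen stands off from the saturated groups much as 2-methylphenyl does, with a 42-fold higher number from compound 2 to compound 4 (1.62 log units; beyond the scatter) and a 4.2-fold higher number from compound 1 to compound 4 (0.62 log units; beyond the scatter), so in these four compounds both aromatic substituents give higher numbers than hexyl and cyclohexyl, and the gap to cyclohexyl is the large one. No measurement on hand offers a reason for either the flat step or the gap to the saturated groups.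

The exchange changes the methyl and the ring atom together, so unsubstituted phenyl or 6-methylpyridin-2-yl on the same nitrogen would be needed to separate the two contributions, and a flat result there could mean they cancel or that neither matters. Also open, going by these compounds, is whether benzyl, with a carbon link to the aromatic ring, or a saturated ring holding an oxygen, such as tetrahydropyran-4-yl, would sit with compound 2 or with compound 3 and compound 4.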